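Swapping isobutyl for 4-chlorophenyl on an amine chain

A few compounds are considered here, and "the series" means these few. Any claim that something is new, unique, unknown or untested is made for them only; others in the source may bear on it.

- compound 1 `CC(C)CCN(C)Cc1ccc(C2=CCCN(C)C2)cc1`: "not determined" (no result reported)
- compound 2 `CN1CCC=C(c2ccc(CN(C)Cc3ccc([N+](=O)[O-])cc3)cc2)C1`: 2290 nM

The measurements come from a functional assay on HL-60 cells (Homo sapiens) for inhibition; on this read-out lower numbers stand for stronger inhibition and higher numbers for weaker inhibition. Compound 1 has no number to stand on, since its entry reads "not determined" (no result reported). Compound 3 `CN1CCC=C(c2ccc(CN(C)Cc3ccc(Cl)cc3)cc2)C1` shares the core of compound 1 and differs from it in one place: 4-chlorophenyl in place of isobutyl on a saturated chain carbon bound to an amine nitrogen. In words, 4-chlorophenyl takes the place of isobutyl on a saturated chain carbon bound to an amine nitrogen. Without a value for compound 1, the size of this step cannot be read from the data. For the measured compounds named here, the only available number is that of compound 2, at 2290 nM. Taking that number as the reference, no shift beyond the usual scatter is expected in this assay, in either direction. For compound 3 the estimated value is 2000 nM, with an expected range of 700 nM to 6000 nM.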

Compound 3, half-maximal inhibitory concentration: 2140 nM
Beside the measured number, compound 3's estimate is 1.1-fold (0.03 log units) below it, within the range that was stated.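

In this assay, chloro in place of nitro on an aromatic carbon gives a 1.1-fold lower number from compound 2 to compound 3 (0.03 log units; within the scatter). For the compounds shown here, this is the first comparison that can be read in the set, and it shows that these two groups cannot be told apart at this position on this read-out, so swapping one for the other leaves the number within the noise of the assay. No measurement is at hand that could explain this result.

On these data alone, compound 1 reads "not determined" (no result reported), so the step from isobutyl to 4-chlorophenyl on a saturated chain carbon bound to an amine nitrogen cannot be read, and the weight of that chain stays unknown. As far as these compounds go, it also remains open whether a methoxy group, a carboxylic acid or a plain hydrogen on that aromatic carbon would read the same as chloro and nitro.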